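Methoxy on the acetamido chain of compound 2

The source may report more compounds than this note shows. Statements on the series, on what has been measured and on what is new or still open speak of the compounds shown alone.

In a functional assay on A2780 cells (Homo sapiens) for antiproliferative activity, read by MTT assay, with a stated time of 48 h (on this read-out higher numbers stand for weaker inhibition and lower numbers for stronger inhibition), compound 1 `C=C(c1ccc2c(c1)C=CC(C)(C)O2)c1ccc(OC)cc1NC(=O)CN` gives 140 nM and compound 2 `C=C(c1cc(OC)c(OC)c(OC)c1)c1ccc(OC)c(O)c1NC(C)=O` gives 170 nM so the two values lie within the scatter of each other. Compound 3 `C=C(c1cc(OC)c(OC)c(OC)c1)c1ccc(OC)c(O)c1NC(=O)COC` keeps the core of compound 2 and differs in one place. The change is methoxy in place of hydrogen on a saturated chain carbon bound to a carbonyl carbon with methoxy in place of hydrogen on a saturated chain carbon bound to a carbonyl carbon. Going by the values given here, no measured pair shows this change, so the expectation rests on thin evidence. Compound 1 also carries a group other than hydrogen on such a chain carbon and gives 140 nM although it differs elsewhere too. In this assay the expected change is a 1.2-fold higher number from compound 2 to compound 3 (0.07 log units; within the scatter) and no shift beyond the scatter is expected in either direction. For compound 3 the estimate is 200 nM with an expected range from 70 nM to 600 nM in this measurement.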

Compound 3, half-maximal inhibitory concentration: 450 nM
For compound 3 the middle estimate is 2.3-fold (0.35 log units) below the measured one; low and high end bracket the measured number.
By their numbers in this assay, from the lowest: compounds 1 and 2 (each within the scatter of the next); then compound 3.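

Methoxy in place of hydrogen on a saturated chain carbon bound to a carbonyl carbon now has a measured step: in this assay the change gives a 2.6-fold higher number from compound 2 to compound 3 (0.42 log units; beyond the scatter). On this core, the position does not take the added methoxy without a loss of inhibition, although this rests on a single pair. Compound 1 also carries a group other than hydrogen on such a chain carbon and gives 140 nM, but it differs elsewhere too, so it does not show how that group compares on this core.

Nothing measured here accounts for the step. Open, going by these compounds, is whether the loss is particular to methoxy or extends to other groups on this chain carbon, such as a carboxylic acid or ethoxy.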